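A few compounds are considered here, and "the series" means these few. Any claim that something is new, unique, unknown or untested is made for them only; others in the source may bear on it.

Measured compounds in a functional assay on DU-145 cells (Homo sapiens) for cytotoxicity, read by MTT assay, with a stated time of 96 h; on this read-out lower numbers stand for an effect already at smaller amounts and higher numbers for an effect only at larger amounts of compound:
compound 1 `N#C/C(=C\c1c(-c2ccccc2)[nH]c2ccccc12)C(=O)c1cccs1`: 11000 nM
compound 2 `O=C(C(=Cc1c(-c2ccccc2)[nH]c2ccccc12)C(=O)c1ccccc1)c1ccccc1`: > 100000 nM
compound 3 `CC(=O)/C(=C/c1c(-c2ccccc2)[nH]c2ccccc12)C(=O)c1ccccc1`: > 100000 nM

For compound 3 the entry > 100000 nM is a limit of the assay and not a number. For compound 2 the entry > 100000 nM is likewise a limit. For the measured compounds named here, compound 1 thus holds the only number in the set, while the two other entries sit at the limit of > 100000 nM in this assay, at which 2 of the 3 values shown sit. Going by the values given here, no two measured compounds differ in a single place, so no measured step is available; compounds 2 and 3 show only that both stay at the limit where compound 1 gives a number.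

Compound 4 `COCCOC(=O)/C(C#N)=C/c1c(-c2ccccc2)[nH]c2ccccc12` is to be measured in this assay. It differs from compound 1 in one place: 2-methoxyethoxy in place of thiophen-2-yl on a carbonyl carbon. The nitrile is kept, and the carbonyl carbon passes from (thiophen-2-yl)carbonyl to (2-methoxyethoxy)carbonyl. Among the compounds with values here, with no measured step of this kind to lean on, the expected step of a 1.4-fold higher number from compound 1 to compound 4 (0.13 log units; within the scatter) is set small, within the scatter, with a limit outcome kept open as a risk. Compound 4 is expected to give about 15000 nM, in the range 4000 nM to 60000 nM.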

Compound 4, half-maximal effective concentration: 4200 nM
For compound 4 the middle estimate is 3.6-fold (0.55 log units) above the measured one; the range from low to high includes it.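

In this assay, for the compounds shown here, the group on this carbonyl carbon can be exchanged with a readable effect, and the first measured step is 2-methoxyethoxy in place of thiophen-2-yl: a 2.6-fold lower number from compound 1 to compound 4 (0.42 log units; beyond the scatter). A five-membered aromatic ring on this carbonyl carbon is therefore not needed for a numerical value in this assay, as the ring-free 2-methoxyethoxy group, with the nitrile kept, gives a number on the lower side of compound 1, although the step is only modest. For compounds 2 and 3 the entries are limits of the assay and not numbers, so they give no size for any step: the limit of > 100000 nM in this assay, at which 2 of the 4 values shown sit.

As far as these compounds go, this single step cannot separate the loss of thiophen-2-yl from the entry of the 2-methoxyethoxy chain, so it remains open whether a shorter methoxy group, a longer chain of the same kind, a carboxylic acid or an amine on this carbonyl carbon would carry the number further down or back up. Also open is what an exchange of the nitrile alone would do with the rest of compound 4 held constant, since no single-place step at that group is available in the compounds shown.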